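The Same Sulfonyl Swap Carried Onto a Second Core

A few compounds are considered here, and "the series" means these few. Any claim that something is new, unique, unknown or untested is made for them only; others in the source may bear on it.

Compound 1 `CC1CCN(c2c(S(=O)(=O)c3ccc(F)c(Cl)c3)cnc3cc(Cl)ccc23)CC1` and compound 2 `CC1CCN(c2c(S(=O)(=O)c3cc(F)cc(F)c3)cnc3cc(Cl)ccc23)CC1` share one core and differ only at the sulfonyl sulfur. In an assay on isolated protein for displacement of a labelled ligand from metabotropic glutamate receptor 5 (Homo sapiens), with a stated time of 60 min, tested at 1 uM (a higher number here means more inhibition at the concentration tested (going by the name of the read-out), a lower number less inhibition), compound 1 gives 94%, and compound 2 gives 94%. The change 3,5-difluorophenyl in place of 3-chloro-4-fluorophenyl on a sulfonyl sulfur thus made no change at the digits printed from compound 1 to compound 2 (within the scatter). Compound 3 `Cc1ccc2ncc(S(=O)(=O)c3ccc(F)c(Cl)c3)c(N3CCC(C)CC3)c2c1` carries a different core; the difference between the two cores is not broken down here. In this assay compound 3 gives 93%, a number within the scatter of both compound 1 and compound 2. Compound 4 `Cc1ccc2ncc(S(=O)(=O)c3cc(F)cc(F)c3)c(N3CCC(C)CC3)c2c1` is compound 3 with the same change, (3,5-difluorophenyl in place of 3-chloro-4-fluorophenyl on a sulfonyl sulfur), made at the same place. The step from compound 3 to compound 4 is expected to be no change at the digits printed from compound 3 to compound 4 (within the scatter). That expectation rests on the earlier change, which gave no change at the digits printed from compound 1 to compound 2 (within the scatter), and on compound 3 already standing at 93%. Compound 4 is therefore estimated to give 93% in this assay, between 85% and 97%.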

Compound 4, a percentage reported as inhibition, at one concentration (the size of the read-out at that concentration, not a potency): 72%
Compound 4: the middle estimate sits 21 percentage points above what was measured; the whole stated range lies above it.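

In this assay, the change to 3,5-difluorophenyl on the core of compound 3 gave a number 21 percentage points lower from compound 3 to compound 4 (beyond the scatter). Set beside the result on the first core, the two steps differ: the same change on two cores in this assay, no change at the digits printed (within the scatter) from compound 1 to compound 2 and a number 21 percentage points lower (beyond the scatter) from compound 3 to compound 4, 21 percentage points apart, beyond the scatter of two such steps. This shows that, in this pair of cores, the outcome of the change on one core did not carry over to the other, but it does not show why, and two pairs of single-concentration readings set no rule for other cores in the series.

Which difference between the two cores goes with this gap remains open. So does whether the gap would recur with another group on the sulfonyl sulfur, such as an unsubstituted phenyl or a phenyl carrying an amine or a carboxylic acid.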